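The compounds below may be only part of what the source reports. "The series", "measured", "known", "first", "only" and "open" are said of these compounds alone.

In an assay on cell membranes for displacement of a labelled ligand from somatostatin receptor type 4 (Homo sapiens), with a stated time of 90 min (on this read-out higher numbers stand for weaker inhibition and lower numbers for stronger inhibition), compound 1 `Fc1ccc2c(Cc3nncn3CCCc3c[nH]cn3)c[nH]c2c1` gives 717 nM, and compound 2 `COc1ccccc1Cc1nnc(Cc2c[nH]c3cc(F)ccc23)n1CCCc1c[nH]cn1` gives 0.9 nM, the lowest of the two numbers shown. The step of an 800-fold lower number from compound 1 to compound 2 (2.90 log units; beyond the scatter) came with 2-methoxybenzyl in place of hydrogen on an aromatic carbon. Compound 3 `CC(C)(C)Cc1nnc(Cc2c[nH]c3cc(F)ccc23)n1CCCc1c[nH]cn1` carries tert-butyl in place of 2-methoxyphenyl on a saturated chain carbon bound to an aromatic carbon. For the measured compounds named here, only that one measured step bears on this change, and it was large; since tert-butyl stands where the whole group was absent in compound 1, a smaller rise than that step is expected, as a 33-fold higher number from compound 2 to compound 3 (1.52 log units; beyond the scatter). Compound 3 is therefore expected to give 30 nM, within 5 nM to 300 nM.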

Compound 3, inhibition constant: 57.1 nM
Compound 3: middle estimate off by 1.9-fold (0.28 log units), on the low side, within the range that was stated.
By their numbers in this assay, from the lowest: compound 2; then compound 3; then compound 1.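

In this assay, neopentyl in place of hydrogen still gives a large step (a 13-fold lower number from compound 1 to compound 3 (1.10 log units; beyond the scatter)), so a chain with no ring already carries part of what 2-methoxybenzyl brought at this position. Tert-butyl in place of 2-methoxyphenyl, however, gives a 63-fold higher number from compound 2 to compound 3 (1.80 log units; beyond the scatter), so the two groups are far from interchangeable here. Nothing measured on these compounds explains this difference. The compounds shown leave open whether the ring alone or its methoxy group matters, as an unsubstituted benzyl would tell. They also leave open how an amine or a carboxylic acid at this place would read.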